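A few compounds are considered here, and "the series" means these few. Any claim that something is new, unique, unknown or untested is made for them only; others in the source may bear on it.

Compound 1 `Cc1cc(C)n(-c2nc(C(F)(F)F)cc(=O)[nH]2)n1` is the simpler of the two measured compounds, and in a physicochemical assay for solubility, at pH 7.4 (on this read-out higher numbers stand for higher solubility and lower numbers for lower solubility), compound 1 gives 200000 nM. Compound 2 `Cc1cc(Nc2ccc(F)cc2F)n(-c2nc(C(F)(F)F)cc(=O)[nH]2)n1` carries in addition a 2,4-difluorophenyl group attached through a nitrogen to the shared core. In this assay compound 2 reaches only a limit, < 5000 nM, so no exact number is known for it, as stated by the limit of < 5000 nM in this assay, at which 1 of the 2 values shown sits. Compound 3 `Cc1cc(Nc2ccccn2)n(-c2nc(C(F)(F)F)cc(=O)[nH]2)n1` differs from compound 2 in one place: pyridin-2-yl in place of 2,4-difluorophenyl on a nitrogen on an aromatic ring, in words pyridin-2-yl in place of 2,4-difluorophenyl on a nitrogen on an aromatic ring. For the measured compounds named here, no step between two measured compounds is available to show what such an exchange does in this assay, and the reading for compound 2 is itself only a limit, so any expectation rests on thin ground. The expected step from compound 2 to compound 3 is an at least 2.0-fold higher number from compound 2 to compound 3 (0.30 log units; that floor lies within the scatter), a modest rise in solubility rather than none, with wide uncertainty. Compound 3 is therefore expected to give about 10000 nM in this assay, within a range from 2000 nM to 50000 nM, and there remains a real chance that this assay again reports only a limit.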

Compound 3, solubility: 25000 nM
The estimate for compound 3 lay 2.5-fold (0.40 log units) below the measured number; the range from low to high includes it.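

In this assay, putting pyridin-2-yl in place of 2,4-difluorophenyl on a nitrogen on an aromatic ring turns a reading that was only a limit into a real number, and the step is an at least 5.0-fold higher number from compound 2 to compound 3 (0.69 log units; beyond the scatter). For the compounds shown here, compound 2 remains a limit and not a number, so this step gives only a floor, and its true size could be larger: the limit of < 5000 nM in this assay, at which 1 of the 3 values shown sits. Exchanging methyl for (pyridin-2-yl)amino on an aromatic carbon now also has a measured size, an 8.0-fold lower number from compound 1 to compound 3 (0.90 log units; beyond the scatter), so the cost of this larger group at this place can be read as a number for the first time.

On these data alone, whether the higher number goes with the ring nitrogen or with the loss of the two fluorines stays open, as this exchange changes both at once, and a plain phenyl on the same nitrogen would separate the two. Also open, as far as these compounds go, is how a pyridin-3-yl group or a saturated amine such as morpholine would read at this place, and a single pair of compounds supports no general rule.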